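Swapping methyl for chloro on the benzyl ring

This account rests on a few compounds, and the source may have more. Where it says the series, first, only, none or still open, it means among the compounds named here.

Measured so far:
compound 1, `O=c1ccoc2cc(OCc3cn(Cc4ccccc4)nn3)ccc12`, gives > 100000 nM in a functional assay on QGY7701 cells (Homo sapiens) for cytotoxicity, read by MTT assay, with a stated time of 48 h (a higher number here means a weaker inhibitor, a lower number a stronger inhibitor), which is a limit of the assay and not a number.
compound 2, `Cc1ccc(Cn2cc(COc3ccc4c(=O)ccoc4c3)nn2)cc1`, gives 68500 nM in this assay.

For the measured compounds named here, compound 2 stands as the only true number in this set; the value of compound 1 is a limit, the one described by the limit of > 100000 nM in this assay, at which 1 of the 2 values shown sits. Going by the values given here, the single measured step, an at least 1.4-fold lower number from compound 1 to compound 2 (0.16 log units; that floor lies within the scatter), is only a floor and lies within the usual scatter, so it shows no clear change from one compound to the other.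

Compound 3, `O=c1ccoc2cc(OCc3cn(Cc4ccc(Cl)cc4)nn3)ccc12`, has not yet been tested. It differs from compound 2 by chloro in place of methyl on an aromatic carbon. Among the compounds with values here, no measured step replaces methyl with chloro; the one step at hand concerns methyl in place of hydrogen and sets no size beyond the scatter, so no step beyond the scatter is expected in this assay either. The expected step is a 1.1-fold lower number from compound 2 to compound 3 (0.06 log units; within the scatter). The estimate for compound 3 is 60000 nM, expected to fall between 20000 nM and 200000 nM.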

Compound 3, half-maximal inhibitory concentration: 41700 nM
For compound 3 the middle estimate is 1.4-fold (0.16 log units) above the measured one; measured number inside the range.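

Chloro in place of hydrogen on the aromatic carbon para to a large group gives the first step in this set that clearly lies beyond the scatter in this assay, with an at least 2.3-fold lower number from compound 1 to compound 3 (0.37 log units; beyond the scatter). That figure is only a floor, because compound 1 stands at a limit of the assay and not at a number: the limit of > 100000 nM in this assay, at which 1 of the 3 values shown sits. Chloro in place of methyl at the same carbon gives a 1.6-fold lower number from compound 2 to compound 3 (0.22 log units; within the scatter), so this change separates compound 2 and compound 3 by no more than repeated measurements would, and the two groups cannot be told apart here.

The compounds shown leave open whether other groups on this carbon, such as a methoxy group, an amine or a carboxylic acid, would behave like chloro, and whether chloro would give the same result on another carbon of the benzyl ring. On these data alone, compound 1 also carries no true number, so the full size of the steps that start from it remains unknown.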